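A few compounds are considered here, and "the series" means these few. Any claim that something is new, unique, unknown or untested is made for them only; others in the source may bear on it.

Measured so far in an ADME assay on Akata cells (Homo sapiens) for cytotoxicity, read by XTT assay; a lower number here means that less compound is tolerated, a higher number that more compound is tolerated:

compound 1 `Cc1ccccc1Cn1cc(Nc2ccccc2)c(=O)[nH]c1=O`: compound 1 gives a limit of the assay, > 100000 nM.
compound 2 `Cc1cccc(Cn2cc(Nc3ccccc3)c(=O)[nH]c2=O)c1`: compound 2 gives a limit of the assay, > 100000 nM.
compound 3 `Cc1cc(C)cc(Cn2cc(Nc3ccccc3)c(=O)[nH]c2=O)c1`: compound 3 gives 96200 nM.

Going by the values given here, compound 3 holds the only actual number in this assay; the other two values are limits, as the limit of > 100000 nM in this assay, at which 2 of the 3 values shown sit, shows. The step from compound 1 to compound 2 is a step that the two limits leave unreadable from compound 1 to compound 2. The steps to compound 3 are both set against a limit: an at least 1.0-fold lower number from compound 1 to compound 3 (0.01 log units; that floor lies within the scatter) and an at least 1.0-fold lower number from compound 2 to compound 3 (0.01 log units; that floor lies within the scatter), neither of which rises beyond the scatter.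

Compound 4 `O=c1[nH]c(=O)n(Cc2cccc(Cl)c2)cc1Nc1ccccc1` is not yet measured. It differs from compound 3 by 3-chlorophenyl in place of 3,5-dimethylphenyl on a saturated chain carbon bound to an aromatic nitrogen. Among the compounds with values here, no measured step exchanges a methyl for a chlorine on this phenyl, so the only bearing on it comes from the steps just named, and both of those are floors that sit within the scatter. Whether the ring carries one or two methyls, the values stay near the limit. On that basis no step beyond the scatter is expected, a 1.0-fold higher number from compound 3 to compound 4 (0.02 log units; within the scatter), and compound 4 is estimated at 100000 nM, within 45000 nM to 220000 nM, with a fair chance that this assay again returns only a limit.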

Compound 4, half-maximal cytotoxic concentration: > 100000 nM
Compound 4: no number, only a limit; the forecaster's own chance of this, stated with the estimate: 55%; the middle value lies on the limit itself.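

In this assay compound 4 gives > 100000 nM as a limit of the assay and not a number. Going by these compounds alone, this is the first chlorine at this position, and the change to 3-chlorophenyl on a saturated chain carbon bound to an aromatic nitrogen gives an at least 1.0-fold higher number from compound 3 to compound 4 (0.01 log units; that floor lies within the scatter) as a floor only, so it shows no step beyond the scatter but does not fix the size of the step. The steps to compound 4 from compound 1 and compound 2 cannot be read, and a chloro-bearing phenyl now joins the methyl-bearing ones at the same limit of this series: the limit of > 100000 nM in this assay, at which 3 of the 4 values shown sit.

Going by these compounds, how far compound 1, compound 2 and compound 4 truly lie from compound 3 stays open, as compound 3 alone holds a number. Also open, on these data alone, is whether any group at this position would give a step beyond the scatter in this assay, for instance an amine, a carboxylic acid or a longer chain in place of the methyl or chloro on the phenyl.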